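Adding one fluoro to compound 1

The source may report more compounds than this note shows. Statements on the series, on what has been measured and on what is new or still open speak of the compounds shown alone.

Compound 1 `O=c1oc2ccccc2c(N2CCN(c3ccccc3)CC2)c1CO` was tested in a functional assay on WM1361 cells (Homo sapiens) for inhibition, read by MTT assay, with a stated time of 24 h; on this read-out lower numbers stand for stronger inhibition and higher numbers for weaker inhibition. For compound 1 the result is a limit and not a number: > 50000 nM. Two relatives with the same core do give numbers: compound 2 `O=c1oc2ccccc2c(N2CCN(C(c3ccc(F)cc3)c3ccc(F)cc3)CC2)c1CO` reads 29400 nM, and compound 3 `O=c1oc2ccccc2c(N2CCN(C(c3ccccc3)c3ccc(Cl)cc3)CC2)c1CO` reads 30200 nM. Compound 4 `O=c1oc2ccccc2c(N2CCN(c3ccc(F)cc3)CC2)c1CO` is still unmeasured. Its difference from compound 1 is fluoro in place of hydrogen on an aromatic carbon, para to a large group. Going by the values given here, no measured pair shows this kind of change. Compound 1 stands at the limit of > 50000 nM, so no shift beyond the usual scatter is expected. The expected step is a step that the limit leaves unreadable from compound 1 to compound 4. For compound 4 the estimated value is 55000 nM, with an expected range from 30000 nM to 100000 nM.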

Compound 4, half-maximal inhibitory concentration: > 50000 nM
Compound 4 ended at the assay's limit; the forecaster's own chance of this, stated with the estimate: 65%; the middle value is on the limit's open side.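

Compound 1 and compound 4 both end at a limit and not at a number, so no step between them can be read: the limit of > 50000 nM in this assay, at which 2 of the 4 values shown sit.

From the compounds shown here alone, whether going from phenyl to 4-fluorophenyl changes inhibition at all stays open.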